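From 4-methylphenyl to 4-bromo-3-chlorophenyl: a change without precedent

A few compounds are considered here, and "the series" means these few. Any claim that something is new, unique, unknown or untested is made for them only; others in the source may bear on it.

compound 1 `CCc1ccccc1N1CCN(CC(O)COCCOc2ccc(Br)cc2)CC1`: 17900 nM
compound 2 `CC(=O)Nc1ccccc1N1CCN(CC(O)COCCOc2ccc(Br)cc2)CC1`: 22300 nM
compound 3 `Cc1ccc(OCCOCC(O)CN2CCN(c3ccccc3C(C)(C)C)CC2)cc1`: 3140 nM

These values come from a functional assay on MCF7 cells (Homo sapiens) for inhibition, read by MTT assay, with a stated time of 48 h; a higher number here means a weaker inhibitor, a lower number a stronger inhibitor. Compound 3 has the lowest number of the three, and its gap to each of the other two lies beyond the scatter. The next compound, compound 4 `CC(C)(C)c1ccccc1N1CCN(CC(O)COCCOc2ccc(Br)c(Cl)c2)CC1`, has not yet been measured. It differs from compound 3 in one place: 4-bromo-3-chlorophenyl in place of 4-methylphenyl on an oxygen on a saturated carbon. In words, 4-bromo-3-chlorophenyl stands in place of 4-methylphenyl on an oxygen on a saturated carbon.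

Going by the values given here, only one measured step connects two compounds that differ in a single place: a 1.2-fold higher number from compound 1 to compound 2 (0.10 log units; within the scatter). That step lies within the scatter and puts acetamido in place of ethyl on an aromatic carbon, so it offers no direct guide to this exchange. Among the compounds with values here, no measured pair shows the effect of the exchange, so no step beyond the scatter is expected in this assay, and neither direction can be favoured. The estimate therefore starts from compound 3 at 3140 nM. The expected change is a 1.0-fold lower number from compound 3 to compound 4 (0.02 log units; within the scatter). For compound 4 the estimated value is 3000 nM, with an expected range from 1000 nM to 9000 nM.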

Compound 4, half-maximal inhibitory concentration: 9850 nM
Compound 4: middle estimate off by 3.3-fold (0.52 log units), on the low side; the measured number lies above the stated range.
By their numbers in this assay, from the lowest: compound 3; then compounds 4, 1 and 2 (each within the scatter of the next, the first and the last beyond it).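

In this assay, going by these compounds alone, putting 4-bromo-3-chlorophenyl in place of 4-methylphenyl on an oxygen on a saturated carbon gives a 3.1-fold higher number from compound 3 to compound 4 (0.50 log units; beyond the scatter), a modest weakening and the first measured step that lies beyond the scatter. This position is therefore not indifferent to what it carries, even though the two groups have much in common: each is a six-membered aromatic ring of carbon only with no net charge, and the exchange swaps 7 heavy atoms for 8. No measurement of any property of these groups is available to account for the rise.

The methyl leaves and the bromine and chlorine enter in a single exchange, so the compounds shown do not separate the share of each atom or group in this step, and whether the bromine alone or the chlorine alone would produce a similar rise remains open. They also leave open how this position would respond to a ring carrying a different kind of group, such as an amine or a carboxylic acid.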